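Replacing the cyclohexyl group of compound 2

This account rests on a few compounds, and the source may have more. Where it says the series, first, only, none or still open, it means among the compounds named here.

Compound 1 `COc1cc2c(Oc3ccc(NC(=O)Nc4ccc(Cl)c(C(F)(F)F)c4)cc3)ccnc2cc1OCCCCCCC(=O)NO`: 5150 nM
Compound 2 `COc1cc2c(Oc3ccc(NC(=O)NC4CCCCC4)cc3)ccnc2cc1OCCCCCCC(=O)NO`: 600 nM

In a functional assay on MCF7 cells (Homo sapiens) for antiproliferative activity, read by MTT assay (on this read-out higher numbers stand for weaker inhibition and lower numbers for stronger inhibition), compound 2 holds the lower of the two measured numbers, at 600 nM. Compound 3 `COc1cc2c(Oc3ccc(NC(=O)NNC(=O)c4ccccc4F)cc3)ccnc2cc1OCCCCCCC(=O)NO` has ((2-fluorophenyl)carbonyl)amino in place of cyclohexyl on an amide-type nitrogen. Among the compounds with values here, the only measured step at this nitrogen is an 8.6-fold lower number from compound 1 to compound 2 (0.93 log units; beyond the scatter). Compound 1, at 5150 nM, also carries an aromatic ring on that nitrogen, so a higher number is expected, though a smaller change than that step. The expected step is a 3.3-fold higher number from compound 2 to compound 3 (0.52 log units; beyond the scatter). The estimate for compound 3 is 2000 nM, within a range of 500 nM to 8000 nM.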

Compound 3, half-maximal inhibitory concentration: 3600 nM
Compound 3: the middle estimate sits 1.8-fold (0.26 log units) below what was measured; the range from low to high includes it.
By their numbers in this assay, from the lowest: compound 2; then compounds 3 and 1 (each within the scatter of the next).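

In this assay, ((2-fluorophenyl)carbonyl)amino on this amide-type nitrogen does not match cyclohexyl (a 6.0-fold higher number from compound 2 to compound 3 (0.78 log units; beyond the scatter)), so compound 2 keeps the lowest number of the three. Set against 4-chloro-3-(trifluoromethyl)phenyl, the same group gives no separable change (a 1.4-fold lower number from compound 1 to compound 3 (0.16 log units; within the scatter)), so two quite different aromatic groups at this nitrogen read alike and both stand apart from cyclohexyl. No evidence given here explains these differences. As far as these compounds go, it remains open whether a smaller carbon ring such as cyclopentyl, or an open chain such as n-butyl, would hold the number of compound 2. Whether a plain phenyl would behave like the two aromatic groups also stays unanswered.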